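Anilino for chloro on the core of compound 1

The compounds below may be only part of what the source reports. "The series", "measured", "known", "first", "only" and "open" are said of these compounds alone.

Among the measured compounds shown here, compound 1 `N#Cc1c(Cl)nc(SCC(=O)Nn2c(COc3ccc(Cl)cc3Cl)nc3ccccc3c2=O)nc1-c1ccc(Cl)cc1` gives 61.5% in a functional assay on the whole organism (strain albino) for inhibition, with Rattus norvegicus as the target, read by paw edema, with stated times of 1 h and 0.5 h, at a dose of 100 mg/kg by the oral route; a lower number here means less inhibition, a higher number more inhibition at the dose given (going by the name of the read-out); on the numbers so far it sits beside compound 2 `N#Cc1c(Cl)nc(SCC(=O)Nn2c(COc3ccc(Cl)cc3Cl)nc3ccccc3c2=O)nc1-c1ccc(O)cc1`, which gives 67.3%, and the step of a number 5.8 percentage points higher from compound 1 to compound 2 (within the scatter) lies within the scatter. Compound 3 `N#Cc1c(Nc2ccccc2)nc(SCC(=O)Nn2c(COc3ccc(Cl)cc3Cl)nc3ccccc3c2=O)nc1-c1ccc(Cl)cc1` differs from compound 1 by anilino in place of chloro on an aromatic carbon. For the measured compounds named here, the only measured step, hydroxy in place of chloro on an aromatic carbon, concerns another part of the structure and was small, so no measured step bears directly on this change; a step in this assay beyond the scatter is not expected. Compound 3 is therefore estimated at 62%, range 42% to 80%, an expected step of a number 0.5 percentage points higher from compound 1 to compound 3 (within the scatter).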

Compound 3, a percentage reported as inhibition, in the whole organism at one dose (the size of the read-out at that dose, not a potency): 36.5%
For compound 3 the middle estimate is 25.5 percentage points above the measured one; measured number below the stated range.
By their numbers in this assay, from the lowest: compound 3; then compounds 1 and 2 (each within the scatter of the next).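

In this assay, anilino in place of chloro on the aromatic carbon ortho to a cyano group gives a number 25 percentage points lower from compound 1 to compound 3 (beyond the scatter). Among the compounds shown here, this position on the shared core therefore does not accept every replacement of chloro, and this is the only single-place step that lies beyond the scatter. No measured evidence bears on the origin of this step. Open, going by these compounds, is whether a small amine such as methylamino, or a methoxy group, at this position gives the same result as anilino or stays level with chloro.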